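The source may report more compounds than this note shows. Statements on the series, on what has been measured and on what is new or still open speak of the compounds shown alone.

Measured compounds:
compound 1 `Cc1ccc2[nH]c(=O)c(/C=N/Nc3ccc([N+](=O)[O-])cc3)cc2c1`, in a functional assay, read by spectrophotometry, with a stated time of 5 min (a higher number here means a weaker inhibitor, a lower number a stronger inhibitor), compound 1 gives "not active" (no number reported)
compound 2 `Cc1ccc2[nH]c(=O)c(/C=N/c3ccc(C(=O)O)cc3)cc2c1`, in this assay compound 2 gives 409000 nM

Compound 1 has no single number in this assay; it was reported as inactive, so its standing among the measured compounds cannot be placed on a scale. Among the measured compounds shown here, compound 2, the only compound with a number, is a very weak inhibitor in this assay. The new compound 3 `O=c1[nH]c2ccccc2cc1/C=N/Nc1ccc([N+](=O)[O-])cc1` arises from compound 1 by the change (hydrogen in place of methyl on an aromatic carbon), hydrogen in place of methyl on an aromatic carbon. For the measured compounds named here, no pair of measured compounds differing in one place is available, so the size of this step is unknown. A shift of the methyl to hydrogen at that carbon is expected to leave compound 3 close to compound 1, that is, weak or without measurable inhibition in this assay. Compound 3 is therefore estimated at 500000 nM, within 100000 nM to 3000000 nM.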

Compound 3, half-maximal inhibitory concentration: "not active" (no number reported)
Compound 3 has no reported number here, so the estimate cannot be set against anything.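

In this assay compound 3 gives "not active" (no number reported) and compound 1 gives "not active" (no number reported) so no step can be read for hydrogen in place of methyl. The compounds shown leave open what size that step has, if any. Nothing shown explains these two results.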